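The source may hold more compounds than are shown below. What is called first, only, known or untested is meant among the compounds shown, and "the series" means these compounds.

Among the measured compounds shown here, in a functional assay on B16-F10 cells (Mus musculus) for cytotoxicity, read by MTT assay, with a stated time of 72 h (on this read-out lower numbers stand for stronger inhibition and higher numbers for weaker inhibition), compound 1 `FC(F)Oc1ccc2[nH]c(SCc3cn(-c4cccc(Cl)c4Cl)nn3)nc2c1` gives 90500 nM, the lowest of the three numbers measured so far. Compound 3 `Cc1c(NC(=O)Cn2cc(CSc3nc4cc(OC(F)F)ccc4[nH]3)nn2)cccc1[N+](=O)[O-]` gives 103000 nM, which lies within the usual scatter of compound 1, so the two cannot be told apart. For the measured compounds named here, compound 2 `O=[N+]([O-])c1ccc(-n2cc(CSc3nc4cc(OC(F)F)ccc4[nH]3)nn2)cc1` gives 203000 nM; the step of a 2.2-fold higher number from compound 1 to compound 2 (0.35 log units; beyond the scatter) is the only single change measured so far, and it swaps one aromatic group for another. Compound 4 `O=C(Cn1cc(CSc2nc3cc(OC(F)F)ccc3[nH]2)nn1)NC1CCCCC1` has not yet been measured in this assay. It differs from compound 1 by (cyclohexylcarbamoyl)methyl in place of 2,3-dichlorophenyl on an aromatic nitrogen. Going by the values given here, no measured step covers this exact change. Among the compounds with values here, the only measured step, from compound 1 to compound 2, moved the number only modestly, and compound 3, whose group on the aromatic nitrogen also contains a carbonyl and an amide hydrogen, stays within the scatter of compound 1. The step from compound 1 to compound 4 is therefore expected to be small, a 1.2-fold higher number from compound 1 to compound 4 (0.08 log units; within the scatter). Compound 4 is estimated at 110000 nM, with a range from 50000 nM to 250000 nM.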

Compound 4, half-maximal inhibitory concentration: 84700 nM
Beside the measured number, compound 4's estimate is 1.3-fold (0.11 log units) above it, within the range that was stated.
By their numbers in this assay, from the lowest: compounds 4, 1, 3 and 2 (each within the scatter of the next, the first and the last beyond it).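

In this assay, the result shows that this aromatic nitrogen accepts a group with a non-aromatic ring and an amide in place of 2,3-dichlorophenyl, with a 1.1-fold lower number from compound 1 to compound 4 (0.03 log units; within the scatter). Changing only the group on the amide-type nitrogen, from 2-methyl-3-nitrophenyl to cyclohexyl, also leaves the two compounds indistinguishable, with a 1.2-fold lower number from compound 3 to compound 4 (0.08 log units; within the scatter). The clearest gap involving the new compound, a 2.4-fold lower number from compound 2 to compound 4 (0.38 log units; beyond the scatter), is still modest, so these changes to the group do not open a large gap on this read-out.

Nothing available explains these numbers or shows how the groups act. On these data alone, whether an amine, a carboxylic acid or a longer chain on this aromatic nitrogen would stay in the same range remains open.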